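A few compounds are considered here, and "the series" means these few. Any claim that something is new, unique, unknown or untested is made for them only; others in the source may bear on it.

Compound 1 `CCN1CCN(c2cc(C)c3cc(NC(=O)c4ccccc4F)ccc3n2)CC1` gives 38100 nM in a functional assay on SK-BR-3 cells (Homo sapiens) for antiproliferative activity, read by MTT assay, with a stated time of 72 h; on this read-out lower numbers stand for stronger inhibition and higher numbers for weaker inhibition.
Compound 2 `CCN1CCN(c2cc(C)c3cc(NC(=O)c4ccccc4C)ccc3n2)CC1` gives 29200 nM.
Compound 3 `CCN1CCN(c2cc(C)c3cc(NC(=O)c4ccc(OC)cc4)ccc3n2)CC1` gives 9000 nM.

All three share one core and differ only in the aryl group attached to the carbonyl of the amide. Compound 3 stands lowest of the three numbers, and both of its steps to the others lie beyond the scatter, so it is the most potent compound measured here: a 4.2-fold lower number from compound 1 to compound 3 (0.63 log units; beyond the scatter) and a 3.2-fold lower number from compound 2 to compound 3 (0.51 log units; beyond the scatter). Between compound 1 and compound 2, the change is a 1.3-fold lower number from compound 1 to compound 2 (0.12 log units; within the scatter).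

Compound 4 `CCN1CCN(c2cc(C)c3cc(NC(=O)c4cccc(F)c4)ccc3n2)CC1` has not yet been measured. Relative to compound 3, the change is 3-fluorophenyl in place of 4-methoxyphenyl on a carbonyl carbon. Among the compounds with values here, no measured pair shows a 3-fluorophenyl, so the nearest guides are the two steps into compound 3, in which the 4-methoxyphenyl gave a lower number than either a 2-fluorophenyl or a 2-methylphenyl. Reading those steps in reverse suggests that replacing the 4-methoxyphenyl is more likely to raise the number than lower it, though a fluorine at a different position may not behave like that in compound 1. Compound 4 is therefore expected to give a weaker number than compound 3, by about a 2.2-fold higher number from compound 3 to compound 4 (0.35 log units; beyond the scatter). The estimate for compound 4 is 20000 nM, within a range from 7000 nM to 60000 nM.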

Compound 4, half-maximal inhibitory concentration: 24900 nM
Compound 4: the middle estimate sits 1.2-fold (0.10 log units) below what was measured; the measured number falls inside the stated range.
By their numbers in this assay, from the lowest: compound 3; then compounds 4, 2 and 1 (each within the scatter of the next).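

The new compound shows that in this assay a fluorine on this aryl group does not bring the number close to that of compound 3, whichever of the two printed fluorophenyl groups is present (a 2.8-fold higher number from compound 3 to compound 4 (0.44 log units; beyond the scatter)). Moving from the 2-fluorophenyl to the 3-fluorophenyl makes no difference that can be told from scatter (a 1.5-fold lower number from compound 1 to compound 4 (0.18 log units; within the scatter)), and the 3-fluorophenyl cannot be told apart from the 2-methylphenyl either (a 1.2-fold lower number from compound 2 to compound 4 (0.07 log units; within the scatter)). Among these four amides, compound 3 now stands alone with its 4-methoxyphenyl while the other three form one group, and no measurement at hand gives a reason for that separation.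

In compound 3 the methoxy group and its ring position change together, so these compounds cannot tell which of the two goes with the lower number; a 3-methoxyphenyl and a 4-fluorophenyl on the same carbonyl carbon would pull them apart. Also open, as far as these compounds go, is whether the 4-methoxyphenyl result extends to other groups, such as a 4-ethoxyphenyl with its longer chain or a 4-aminophenyl with an amine.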